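This account rests on a few compounds, and the source may have more. Where it says the series, first, only, none or still open, it means among the compounds named here.

Compound 1 `Cc1cc(CN(CC2CCCC2)[C@@H](CC(=O)O)c2ccc(Cl)cc2)ccc1OCCN1C(=O)CCC1=O` was tested in an ADME assay on liver (Mus musculus) for metabolic stability, read by LC-MS, using microsomes and NADPH; a higher number here means that more of the compound is left, a lower number that less of the compound is left. Compound 1 gives 69%. Compound 2 `CCN(Cc1ccc(OCCn2c(=O)ccn(C)c2=O)c(C)c1)C(CC(=O)O)c1ccc(Cl)cc1` shares a related but distinct core, and the difference between the two cores is not broken down here; in this assay compound 2 gives 37%, while compound 3 `CCCN(Cc1ccc(OCCn2c(=O)ccn(C)c2=O)c(C)c1)C(CC(=O)O)c1ccc(Cl)cc1` gives 23%. Compound 3 carries one change relative to compound 2, namely (methyl in place of hydrogen on a saturated chain carbon, two bonds along the chain from an amine nitrogen), and that change produced a number 14 percentage points lower from compound 2 to compound 3 (beyond the scatter). Compound 4 `CCc1cc(CN(CC2CCCC2)[C@@H](CC(=O)O)c2ccc(Cl)cc2)ccc1OCCN1C(=O)CCC1=O` has not yet been measured. It differs from compound 1 by methyl in place of hydrogen on a saturated chain carbon bound to an aromatic carbon. Going by the values given here, this is the same kind of change as the one from compound 2 to compound 3, but the surroundings differ: in one case the carbon is bound to an aromatic carbon, in the other it is two bonds along the chain from an amine nitrogen. Among the compounds with values here, with only one earlier example to go on, the expected step for compound 4 is a number 14 percentage points lower from compound 1 to compound 4 (beyond the scatter), because a drop of the size seen in a number 14 percentage points lower from compound 2 to compound 3 (beyond the scatter) is the only guide available. For compound 4 the estimate is therefore 55%, with a range from 38% to 70%.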

Compound 4, percent of the compound remaining: 27%
Beside the measured number, compound 4's estimate is 28 percentage points above it; measured number below the stated range.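

In this assay, putting methyl in place of hydrogen on the saturated chain carbon bound to an aromatic carbon gave a number 42 percentage points lower from compound 1 to compound 4 (beyond the scatter). The direction matched the earlier example, but the size did not carry over from one core to the other: the same change on two cores in this assay, a number 14 percentage points lower (beyond the scatter) from compound 2 to compound 3 and a number 42 percentage points lower (beyond the scatter) from compound 1 to compound 4, 28 percentage points apart, beyond the scatter of two such steps These two examples therefore show a drop both times, but they give no size that can be transferred, and since both the core and the place of the change differ, they cannot show which of the two governs the size.

The compounds shown leave open how a longer chain such as propyl, or a chlorine, would read in this assay in place of the ethyl of compound 4. Also open, as far as these compounds go, is what the methyl to ethyl change does on the core of compound 2.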